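The compounds below may be only part of what the source reports. "The series", "measured", "known", "first", "only" and "open" are said of these compounds alone.

Measured so far in a functional assay on MDA-MB-231 cells (Homo sapiens) for cytotoxicity, read by MTT assay, with a stated time of 48 h; on this read-out lower numbers stand for stronger inhibition and higher numbers for weaker inhibition:
- compound 1 `COc1ccc(N/C=C\C(=O)c2nc(-c3ccc(C(F)(F)F)cc3)n3ccccc23)cc1OC`, for which compound 1 gives > 30000 nM, a limit of the assay.
- compound 2 `O=C(/C=C\Nc1ccc(Cl)cc1)c1nc(-c2ccc(C(F)(F)F)cc2)n2ccccc12`, for which compound 2 gives 3840 nM.
- compound 3 `COc1ccc(N/C=C\C(=O)c2nc(-c3ccc(F)cc3)n3ccccc23)cc1OC`, for which compound 3 gives > 30000 nM, a limit of the assay.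

Two of the three values sit at the same limit (the limit of > 30000 nM in this assay, at which 2 of the 3 values shown sit). Among the measured compounds shown here, the one readable step is an at least 7.8-fold lower number from compound 1 to compound 2 (0.89 log units; beyond the scatter), made by the change (4-chlorophenyl in place of 3,4-dimethoxyphenyl on an amine nitrogen). The other measured step, a step that the two limits leave unreadable from compound 1 to compound 3, is made by fluoro in place of trifluoromethyl on an aromatic carbon; both values in that pair are limits, so its size cannot be read.

Compound 4 `O=C(/C=C\Nc1ccc(Cl)cc1)c1nc(-c2ccc(F)cc2)n2ccccc12` is not yet measured in this assay. It differs from compound 3 by 4-chlorophenyl in place of 3,4-dimethoxyphenyl on an amine nitrogen, which is the same change as that from compound 1 to compound 2: the place line reads the same word for word in both pairs, and the leaving and entering groups are the same. The core of compound 3 and compound 4 differs from the core of compound 1 and compound 2 only in the fluoro in place of trifluoromethyl already told above.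

The expected step of an at least 3.7-fold lower number from compound 3 to compound 4 (0.57 log units; beyond the scatter) is taken from the measured pair, because compound 1 to compound 2 gave an at least 7.8-fold lower number from compound 1 to compound 2 (0.89 log units; beyond the scatter); the start point here is itself a limit, so the expected size is held loosely. Compound 4 is accordingly estimated at 8000 nM, with a range from 2500 nM to 30000 nM.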

Compound 4, half-maximal inhibitory concentration: 4250 nM
Compound 4: the middle estimate sits 1.9-fold (0.27 log units) above what was measured; measured number inside the range.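

In this assay, 4-chlorophenyl in place of 3,4-dimethoxyphenyl on an amine nitrogen is carried from the core of compound 1 to the core of compound 3, with an at least 7.0-fold lower number from compound 3 to compound 4 (0.84 log units; beyond the scatter), and the two steps point the same way on both cores: the same change on two cores in this assay, an at least 7.8-fold lower number (0.89 log units; beyond the scatter) from compound 1 to compound 2 and an at least 7.0-fold lower number (0.84 log units; beyond the scatter) from compound 3 to compound 4; the limit leaves it open whether they differ. This shows that the change lowers the number on both cores, but each step starts from a limit of the assay rather than a number, so only a minimum size is known for each and equal size on the two cores is not shown: the limit of > 30000 nM in this assay, at which 2 of the 4 values shown sit. With 4-chlorophenyl on the amine nitrogen, fluoro in place of trifluoromethyl gives a 1.1-fold higher number from compound 2 to compound 4 (0.04 log units; within the scatter), which lies within the scatter, while the matching step with 3,4-dimethoxyphenyl cannot be read.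

Two cores and one pair of amine nitrogen groups are a narrow base, and they leave open whether the same step would appear with a plain phenyl or a 4-methoxyphenyl on that nitrogen. Also open, from the compounds shown here alone, is whether the fluoro and trifluoromethyl positions would tolerate a carboxylic acid or an amine with 4-chlorophenyl kept in place.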